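The source may hold more compounds than are shown below. What is called first, only, known or untested is meant among the compounds shown, and "the series" means these compounds.

The measured compounds:

Compound 1 `O=C1CC(c2ccccc2OCc2ccc(F)cc2)Oc2ccccc21` — in a functional assay on J774.A1 cells (Mus musculus) for inhibition, read by immunoassay, with a stated time of 12 h, tested at 30 uM (a lower number here means less inhibition, a higher number more inhibition at the concentration tested (going by the name of the read-out)), compound 1 gives 42.1%.
Compound 2 `CC(C)CCOc1ccccc1C1CC(=O)c2ccccc2O1` — in this assay compound 2 gives 43.6%.

Compound 2 stands alongside compound 1 on these numbers: the step of a number 1.5 percentage points higher from compound 1 to compound 2 (within the scatter) lies within the scatter, so the two are not distinguished. Compound 3 `CCCOc1ccccc1C1CC(=O)c2ccccc2O1` is not yet measured. It differs from compound 2 by methyl in place of isopropyl on a saturated chain carbon, two bonds along the chain from an oxygen on an aromatic ring. Within the data shown here, the only measured step, a number 1.5 percentage points higher from compound 1 to compound 2 (within the scatter), also alters the chain carried by the oxygen on the aromatic ring, and it left the read-out unchanged within the scatter. Among the measured compounds shown here, that step is the only guide, and it points to no step beyond the scatter when the chain is shortened from isopentyloxy to propoxy. Compound 3 is therefore estimated at 42% in this assay, within a range of 25% to 58%. The expected step of a number 1.6 percentage points lower from compound 2 to compound 3 (within the scatter) amounts to no change beyond the scatter.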

Compound 3, a percentage reported as inhibition, at one concentration (the size of the read-out at that concentration, not a potency): 43.6%
Compound 3: middle estimate off by 1.6 percentage points, on the low side; low and high end bracket the measured number.
By their numbers in this assay, from the lowest: compounds 1, 2 and 3 (each within the scatter of the next).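

In this assay, methyl in place of isopropyl on a saturated chain carbon, two bonds along the chain from an oxygen on an aromatic ring, gives no change at the digits printed from compound 2 to compound 3 (within the scatter), so shortening isopentyloxy to propoxy does not distinguish the two compounds. The earlier step changed only the end of the chain from 4-fluorophenyl to isobutyl; the new one, ethyl in place of 4-fluorophenyl, gives a number 1.5 percentage points higher from compound 1 to compound 3 (within the scatter), so the propoxy chain is likewise not distinguished from the chain ending in 4-fluorophenyl. No evidence is available to explain this insensitivity to the chain.

The compounds shown leave open whether an amine or a carboxylic acid at the end of the chain would move the read-out beyond the scatter. They also leave open what a much longer chain, or a bare hydroxyl at this oxygen, would give.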